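This account rests on a few compounds, and the source may have more. Where it says the series, first, only, none or still open, it means among the compounds named here.

Compound 1 `CN1CCN(c2ccc(Nc3nc(-c4cccc(NC(=O)c5cccc(F)c5)c4)sc3C(=O)O)cc2)CC1` and compound 2 `CN1CCN(c2ccc(Nc3nc(-c4cccc(NC(=O)c5ccccc5F)c4)sc3C(=O)O)cc2)CC1` share one core and differ only at the outer end of the amide-bearing side chain. In a functional assay on Ramos cells (Homo sapiens) for antiproliferative activity, read by CCK-8 assay, with a stated time of 72 h (a lower number here means a stronger inhibitor, a higher number a weaker inhibitor), compound 1 gives 14000 nM, while compound 2 gives 6300 nM. The change between them is described by 2-fluorophenyl in place of 3-fluorophenyl on a carbonyl carbon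
, and it produced a 2.2-fold lower number from compound 1 to compound 2 (0.35 log units; beyond the scatter). Compound 3 `CN1CCN(c2ccc(Nc3nc(-c4cccc(NC(=O)c5cccc(F)c5)c4)sc3C(N)=O)cc2)CC1` carries the same 3-fluorophenyl group as compound 1 but differs from it in the core, as described by amino in place of hydroxy on a carbonyl carbon
. In this assay, going by these compounds, compound 3 is recorded as "not determined" (no result reported), so no number was obtained for it and the effect of that core change on potency remains unknown. Compound 4 `CN1CCN(c2ccc(Nc3nc(-c4cccc(NC(=O)c5ccccc5F)c4)sc3C(N)=O)cc2)CC1` stands to compound 3 exactly as compound 2 stands to compound 1: the difference is described by 2-fluorophenyl in place of 3-fluorophenyl on a carbonyl carbon
, and the place of the change, on a carbonyl carbon whose other neighbours are an amide-type nitrogen, is the same as before. This is the same kind of change as the step from compound 1 to compound 2, made on the amide core instead of the acid core. Going by the values given here, the expected step from compound 3 to compound 4 in this assay is therefore of a similar modest size as the measured one, resting on the single precedent of compound 1 to compound 2 given by a 2.2-fold lower number from compound 1 to compound 2 (0.35 log units; beyond the scatter), with the caveat that the core of compound 3 and compound 4 has no measured anchor. Taking compound 2 as the nearest measured reference because of 6300 nM, compound 4 is estimated at 5000 nM, with a plausible range from 1000 nM to 30000 nM.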

Compound 4, half-maximal inhibitory concentration: 1360 nM
Estimate against measurement, compound 4: 3.7-fold (0.57 log units) above; the measured number falls inside the stated range.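

With the 2-fluorophenyl group held fixed, amino in place of hydroxy on a carbonyl carbon gives a 4.6-fold lower number from compound 2 to compound 4 (0.67 log units; beyond the scatter) in this assay, so on this one pair the amide core reads as the stronger of the two. This does not show that the core change would carry over to the 3-fluorophenyl pair, nor that the fluorine shift, which gave a 2.2-fold lower number from compound 1 to compound 2 (0.35 log units; beyond the scatter) on the acid core, repeats on the amide core: compound 3 has no number, so neither of the steps that start from or end at it can be read. The size of the new step therefore rests on a single pair, and nothing shown here bears on what lies behind it.

The compounds shown leave open how a methyl ester or a nitrile would read in place of the carboxylic acid and the amide on this core. They also leave open whether a plain phenyl or a chlorophenyl group on the amide-bearing side chain would follow the same course in this assay on either core.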